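Compound 1 to compound 4: one stereocentre defined

The compounds below may be only part of what the source reports. "The series", "measured", "known", "first", "only" and "open" are said of these compounds alone.

In a functional assay on A-375 cells (Homo sapiens) for cytotoxicity, read by MTT assay, with a stated time of 72 h (on this read-out lower numbers stand for stronger inhibition and higher numbers for weaker inhibition), compound 1 `CC1(C)OCC(Cn2cc(Cn3c4c(c5ccccc53)C(=O)c3c[n+]([O-])c5ccccc5c3C4=O)nn2)O1` gives 330 nM, compound 2 `O=C1c2c[n+]([O-])c3ccccc3c2C(=O)c2c1c1ccccc1n2CCN1CCCC1` gives 430 nM and compound 3 `O=C1c2c[n+]([O-])c3ccccc3c2C(=O)c2c1c1ccccc1n2CCCCN1CCNCC1` gives 460 nM. The three values lie within the scatter of each other, so compound 1 cannot be ranked against the other two.

Compound 4 `CC1(C)OC[C@@H](Cn2cc(Cn3c4c(c5ccccc53)C(=O)c3c[n+]([O-])c5ccccc5c3C4=O)nn2)O1` differs from compound 1 only in how one centre is drawn: the two compounds have the same atoms and bonds; at least one stereo element is drawn with a configuration in one of them and without one in the other: 1 of 1 stereo elements differ; a stereocentre at a saturated ring carbon is drawn without a configuration in compound 1 and R in compound 4. Nothing leaves and nothing enters.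

Going by the values given here, the only measured step between compounds differing in one place is a 1.1-fold higher number from compound 2 to compound 3 (0.03 log units; within the scatter). That step is a side-chain exchange and not a change of configuration, so it bears on this case only indirectly: it shows one structural change that stayed within the scatter. Among the compounds with values here, no measured pair compares two configurations at one centre, so the size of any stereo effect is unknown and the range is kept wide.

The estimate is therefore anchored on compound 1 at 330 nM, and no step beyond the scatter is expected. The estimated step is no change at the digits printed from compound 1 to compound 4 (within the scatter). Compound 4 is expected at 330 nM, with an estimated range of 150 nM to 700 nM.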

Compound 4, half-maximal inhibitory concentration: 450 nM
Compound 4: the middle estimate sits 1.4-fold (0.13 log units) below what was measured; the range from low to high includes it.
By their numbers in this assay, from the lowest: compounds 1, 2, 4 and 3 (each within the scatter of the next).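

In this assay the step at this saturated ring carbon is a 1.4-fold higher number from compound 1 to compound 4 (0.13 log units; within the scatter); defining the centre as R therefore gives no reading that separates compound 4 from compound 1. Going by these compounds alone, this is the first reading at this centre, as the earlier comparison, a 1.1-fold higher number from compound 2 to compound 3 (0.03 log units; within the scatter), concerned a side-chain exchange and said nothing about configuration. With atoms and bonds the same in both compounds, the step can be read against one structural difference only: the fact that one of compounds 1 and 4 is drawn with a defined configuration and the other without, at the place where they differ

No pair shown sets two defined configurations against each other, so whether the S configuration at this ring carbon would read the same as the R configuration of compound 4 remains open. Also open, on these data alone, is whether this centre stays as undemanding in this assay when the saturated ring that carries it gives way to an open-chain diol with two free hydroxyl groups, or to a carboxylic acid on the same side chain.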